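A few compounds are considered here, and "the series" means these few. Any claim that something is new, unique, unknown or untested is made for them only; others in the source may bear on it.

Measured compounds:
- Compound 1 `CC(=O)c1ccc(N2CCN(C(=O)c3nc4cc(Cl)ccc4s3)CC2)cc1` gives 30.8% in an ADME assay on RAW264.7 cells (Mus musculus) for cytotoxicity, read by MTT assay, with a stated time of 72 h, tested at 50 ug/mL; on this read-out higher numbers stand for more inhibition at the one concentration tested (going by the name of the read-out) and lower numbers for less inhibition
- Compound 2 `O=C(c1nc2ccccc2s1)N1CCN(c2ccncc2)CC1` gives 62% in this assay
- Compound 3 `CN1CCN(C(=O)c2nc3ccccc3s2)CC1` gives 52.1% in this assay

Among these three, compound 1 stands lowest. Compound 3 is nearest to it, yet its number lies beyond the scatter above that of compound 1, and compound 2 lies further off still. For the measured compounds named here, the only step between two measured compounds that differ in one place is a number 9.9 percentage points lower from compound 2 to compound 3 (within the scatter), a change at the amine nitrogen in the ring rather than on the aromatic carbon.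

Compound 4 `COc1ccc(N2CCN(C(=O)c3nc4cc(Cl)ccc4s3)CC2)cc1` is not yet measured. It differs from compound 1 in one place: methoxy in place of acetyl on an aromatic carbon. Going by the values given here, no measured step concerns a change on this aromatic carbon, so no measured pair bears directly on it; the one step at hand, at a different place, stayed within the scatter. The account therefore expects no step beyond the scatter in this assay from compound 1 to compound 4. Compound 4 is estimated to give 31%, with a range from 15% to 48%, which means an expected step of a number 0.2 percentage points higher from compound 1 to compound 4 (within the scatter).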

Compound 4, a percentage reported as inhibition, at one concentration (the size of the read-out at that concentration, not a potency): 42.8%
Compound 4: middle estimate off by 11.8 percentage points, on the low side; the measured number falls inside the stated range.
By their numbers in this assay, from the lowest: compound 1; then compounds 4, 3 and 2 (each within the scatter of the next, the first and the last beyond it).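

For the compounds shown here, the exchange of acetyl for methoxy on this aromatic carbon, para to a large group, is the first measured change at this place, and in this assay it gives a number 12 percentage points higher from compound 1 to compound 4 (beyond the scatter). Going by these compounds alone, this shows that the group at this place can shift the percentage beyond the usual scatter, if only modestly, whereas the one earlier step, made at the amine nitrogen in the ring, stayed within it. Nothing at hand accounts for the direction or size of this step.

With only acetyl and methoxy compared here, the compounds shown leave open how an amine, a carboxylic acid or a longer alkoxy chain at this place would read. They also leave open whether the same exchange would give a similar step on another core.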